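A few compounds are considered here, and "the series" means these few. Any claim that something is new, unique, unknown or untested is made for them only; others in the source may bear on it.

Working notes on the series

Compound 1 `COc1cccc(/C=C/C(=O)c2c(OC)cc(OC)c(CC=C(C)C)c2O)c1` carries the shared core and gives 49200 nM in an ADME assay on MCF7-DOX cells (Homo sapiens) for cytotoxicity, read by MTT assay, with a stated time of 48 h; a higher number here means a weaker inhibitor, a lower number a stronger inhibitor. Compound 2 `COc1cc(OC)c(C(=O)/C=C/c2cccc(N3CCNCC3)c2)c(O)c1CC=C(C)C` gives 99900 nM in this assay. Compound 3 `COc1ccc(/C=C/C(=O)c2c(OC)cc(OC)c(CC=C(C)C)c2O)cc1` gives 46900 nM in this assay; the two cores of compound 1 and compound 3 differ as 4-methoxyphenyl in place of 3-methoxyphenyl on a double-bonded chain carbon bound to a double-bonded chain carbon, and the step of a 1.0-fold lower number from compound 1 to compound 3 (0.02 log units; within the scatter) lies within the scatter, so no order between them is claimed.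

The change piperazin-1-yl in place of methoxy on an aromatic carbon produced the step of a 2.0-fold higher number from compound 1 to compound 2 (0.31 log units; beyond the scatter), a modest loss of potency that is beyond the scatter. Compound 4 `COc1cc(OC)c(C(=O)/C=C/c2ccc(N3CCNCC3)cc2)c(O)c1CC=C(C)C` is not yet measured; it differs from compound 3 as piperazin-1-yl in place of methoxy on an aromatic carbon. Among the measured compounds shown here, this is the same kind of change as the one from compound 1 to compound 2, not the same: in compound 2 the entering group sits meta to a large group, in compound 4 para to a large group.

For the measured compounds named here, on the single earlier instance, the step from compound 3 to compound 4 in this assay is expected to be about a 2.0-fold higher number from compound 3 to compound 4 (0.31 log units; beyond the scatter), resting on the step of a 2.0-fold higher number from compound 1 to compound 2 (0.31 log units; beyond the scatter). Compound 4 is therefore estimated at 95000 nM, between 48000 nM and 200000 nM.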

Compound 4, half-maximal inhibitory concentration: 57800 nM
Compound 4: middle estimate off by 1.6-fold (0.22 log units), on the high side; low and high end bracket the measured number.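

On the second core, piperazin-1-yl in place of methoxy on an aromatic carbon, here para to a large group, gives in this assay a 1.2-fold higher number from compound 3 to compound 4 (0.09 log units; within the scatter), a step that does not separate the pair. The two instances of the change cannot be told apart: the same change on two cores in this assay, a 2.0-fold higher number (0.31 log units; beyond the scatter) from compound 1 to compound 2 and a 1.2-fold higher number (0.09 log units; within the scatter) from compound 3 to compound 4, 1.6-fold (0.22 log units) apart, within the scatter of two such steps. This supports carrying the change between these two closely related cores as a small step at most, but two pairs do not fix its size, show that it holds on other cores, or establish any effect of the position of the entering group.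

The compounds shown leave open how morpholine, 4-methylpiperazin-1-yl or an open-chain amine would compare with piperazin-1-yl on the same aromatic carbon, and whether a carboxylic acid there would give a different reading. They also leave open whether the step would persist on a core carrying fluorine in place of the hydroxyl group.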